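Replacing fluoro with butoxy on the shared core

A few compounds are considered here, and "the series" means these few. Any claim that something is new, unique, unknown or untested is made for them only; others in the source may bear on it.

Compound 1 `COc1cc(C(=O)/C=C/c2ccc(Br)cc2)cc(OC)c1OC` in a functional assay on L1210 cells (Mus musculus) for cytotoxicity, read by MTT assay, with a stated time of 24 h (a higher number here means a weaker inhibitor, a lower number a stronger inhibitor), gives > 100000 nM, which is a limit of the assay.
Compound 2 `COc1cc(C(=O)/C=C/c2ccc([N+](=O)[O-])cc2)cc(OC)c1OC` in this assay gives > 100000 nM, also a limit.
Compound 3 `COc1cc(C(=O)/C=C/c2ccc(F)cc2)cc(OC)c1OC` in this assay gives 46500 nM.

Compound 3 is therefore the only one of the three with an actual number; the other two values are limits. Compound 4 `CCCCOc1ccc(/C=C/C(=O)c2cc(OC)c(OC)c(OC)c2)cc1` differs from compound 3 by butoxy in place of fluoro on an aromatic carbon. The measured steps touching this place are an at least 2.1-fold lower number from compound 1 to compound 3 (0.33 log units; beyond the scatter) and an at least 2.1-fold lower number from compound 2 to compound 3 (0.33 log units; beyond the scatter), while a step that the two limits leave unreadable from compound 1 to compound 2 remains unreadable, both values sitting at the limit of > 100000 nM in this assay, at which 2 of the 3 values shown sit. Fluoro gave a lower number than bromo or nitro, but no measured step involves butoxy, so the direction of this change is open. Compound 4 is expected to give 60000 nM, between 15000 nM and 200000 nM, an expected step of a 1.3-fold higher number from compound 3 to compound 4 (0.11 log units; within the scatter).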

Compound 4, half-maximal inhibitory concentration: > 100000 nM
Compound 4: a limit, no number (the forecaster's own chance of this, stated with the estimate: 35%); middle value at least 1.6-fold (0.22 log units) from the limit.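

Butoxy in place of fluoro gives an at least 2.1-fold higher number from compound 3 to compound 4 (0.33 log units; beyond the scatter) in this assay and so loses the measurable number that compound 3 has. The value of compound 4 is a limit, so its steps to compound 1 and compound 2 cannot be read. Among the groups shown at this place on the ring, only fluoro gives an actual number, and the rest cannot be ranked: the limit of > 100000 nM in this assay, at which 3 of the 4 values shown sit.

Still open, as far as these compounds go, is whether methoxy, chloro or an amine here would give a lower number than compound 3. A chain shorter than butoxy is equally untested in the compounds shown.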